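The source may hold more compounds than are shown below. What is called first, only, known or untested is meant among the compounds shown, and "the series" means these compounds.

Measured compounds:
compound 1, `Cc1cc(C(=O)N2CCCCc3ccccc32)ccc1CNC(=O)Nc1c(F)cccc1F`, gives 2.1 nM in a functional assay on HEK293 cells for agonist activity at Vasopressin V2 receptor (Homo sapiens), read by a luciferase reporter and cAMP accumulation; on this read-out lower numbers stand for an effect already at smaller amounts and higher numbers for an effect only at larger amounts of compound;
compound 2, `CCc1cc(C(=O)N2CCCCc3ccccc32)ccc1CNC(=O)Nc1c(F)cccc1F`, gives 10 nM in this assay;
compound 3, `COC(=O)CNC(=O)NCc1ccc(C(=O)N2CCCCc3ccccc32)cc1C`, gives 37 nM in this assay.

Compound 2 differs from compound 1 by methyl in place of hydrogen on a saturated chain carbon bound to an aromatic carbon, a change that read a 4.8-fold higher number from compound 1 to compound 2 (0.68 log units; beyond the scatter). Compound 3 differs from compound 1 in its core by (methoxycarbonyl)methyl in place of 2,6-difluorophenyl on an amide-type nitrogen, and this change read an 18-fold higher number from compound 1 to compound 3 (1.25 log units; beyond the scatter). Compound 4, `CCOC(=O)CNC(=O)NCc1ccc(C(=O)N2CCCCc3ccccc32)cc1C`, has not yet been measured in this assay. It differs from compound 3 by methyl in place of hydrogen on a saturated chain carbon bound to an oxygen next to a carbonyl group. This is the same kind of change as that from compound 1 to compound 2, but the place is not the same: there the methyl enters on a saturated chain carbon bound to an aromatic carbon, here on a saturated chain carbon bound to an oxygen next to a carbonyl group. Because the earlier entry of a methyl gave a 4.8-fold higher number from compound 1 to compound 2 (0.68 log units; beyond the scatter), compound 4 is expected to show a somewhat higher number than compound 3. Going by the values given here, the expected step, a 1.6-fold higher number from compound 3 to compound 4 (0.21 log units; within the scatter), is set smaller than the earlier one; the place of entry differs and no directly comparable pair is available. Compound 4 is thus estimated at 60 nM in this assay, with a range from 20 nM to 180 nM.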

Compound 4, half-maximal effective concentration: 140 nM
Compound 4: middle estimate off by 2.3-fold (0.37 log units), on the low side; the range from low to high includes it.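

In this assay the methyl entering on a saturated chain carbon bound to an oxygen next to a carbonyl group gives a 3.8-fold higher number from compound 3 to compound 4 (0.58 log units; beyond the scatter), while the wider exchange of 2,6-difluorophenyl for (ethoxycarbonyl)methyl gives a 67-fold higher number from compound 1 to compound 4 (1.82 log units; beyond the scatter). The two entries of a methyl, made at different places on different cores, thus read alike: the same change on two cores in this assay, a 4.8-fold higher number (0.68 log units; beyond the scatter) from compound 1 to compound 2 and a 3.8-fold higher number (0.58 log units; beyond the scatter) from compound 3 to compound 4, 1.3-fold (0.10 log units) apart, within the scatter of two such steps. Going by these compounds alone, this shows that the change raised the number by a comparable size in these two pairs, but with only two pairs and two different places, it does not show that the step would carry over to another core or another place, nor why it arises.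

Going by these compounds, whether a longer chain, such as propoxycarbonyl in place of ethoxycarbonyl, would raise the number further remains open. On these data alone, it is also open how a carboxylic acid in place of the ester would read against compound 3 and compound 4.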